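This account rests on a few compounds, and the source may have more. Where it says the series, first, only, none or still open, it means among the compounds named here.

Measured compounds in a functional assay on the whole organism (artery, strain albino) with Rattus norvegicus as the target, with a stated time of 300 min, at a dose of 10 mg/kg by the oral route; on this read-out higher numbers stand for more inhibition at the one dose given (going by the name of the read-out) and lower numbers for less inhibition:

Compound 1, `CC1=C(C(=O)Nc2ccc(F)cc2)C(c2ccc([N+](=O)[O-])cc2)N=C(SCc2ccc(Cl)cc2)N1`: 37.9%
Compound 2, `CC1=C(C(=O)Nc2ccc(F)cc2)C(c2ccc([N+](=O)[O-])cc2)N=C(SCc2ccc(F)cc2)N1`: 30.3%
Compound 3, `CC1=C(C(=O)Nc2ccc([N+](=O)[O-])cc2)C(c2cccc([N+](=O)[O-])c2)N=C(SCc2ccc(Cl)cc2)N1`: 24.1%

Compounds 1 and 2 share a core and differ in a single place. The change is fluoro in place of chloro on an aromatic carbon and its effect on inhibition in this assay is a number 7.6 percentage points lower from compound 1 to compound 2 (within the scatter), so the two values cannot be told apart with confidence. Compound 3 carries a different core; how it differs from compound 1 is not broken down here. What the numbers show is that compound 1 gives a reading beyond the scatter above that of compound 3, while compound 2 and compound 3 lie within the scatter of each other.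

Compound 4, `CC1=C(C(=O)Nc2ccc([N+](=O)[O-])cc2)C(c2cccc([N+](=O)[O-])c2)N=C(SCc2ccc(F)cc2)N1`, has not yet been measured. Among the measured compounds shown here, it is made from compound 3 by fluoro in place of chloro on an aromatic carbon, the same change as the one from compound 1 to compound 2, at the same kind of place. On the core of compound 1 that change produced a number 7.6 percentage points lower from compound 1 to compound 2 (within the scatter). For the measured compounds named here, with only this one precedent, compound 4 is expected to move by about a number 7.1 percentage points lower from compound 3 to compound 4 (within the scatter), because compound 3 starts at 24.1% and the earlier step gives the only guide to direction and size. Compound 4 is therefore estimated to give about 17% in this assay, with a likely range from 5% to 30%.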

Compound 4, a percentage reported as inhibition, in the whole organism at one dose (the size of the read-out at that dose, not a potency): 27.2%
For compound 4 the middle estimate is 10.2 percentage points below the measured one; the range from low to high includes it.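

Set on the core of compound 3, fluoro in place of chloro gives, in this assay, a number 3.1 percentage points higher from compound 3 to compound 4 (within the scatter). Placed beside the earlier step on the core of compound 1, this second step cannot be separated from it: the same change on two cores in this assay, a number 7.6 percentage points lower (within the scatter) from compound 1 to compound 2 and a number 3.1 percentage points higher (within the scatter) from compound 3 to compound 4, 10.7 percentage points apart, within the scatter of two such steps. On these two cores the change therefore leaves the reading within the scatter each time, which fits a small effect of the swap in this series, but the two steps do not establish a shared direction or size, and two cores say nothing firm about how the change would behave on a third.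

The compounds shown carry only chloro or fluoro at this place, so it remains open what a methyl group, a methoxy group, a trifluoromethyl group or an amine would do there, or whether a longer chain in place of the 4-chlorobenzyl group would shift the reading. As far as these compounds go, each reading is also a single one at one dose, so how these compounds would compare across a range of doses stays open as well.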